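This account rests on a few compounds, and the source may have more. Where it says the series, first, only, none or still open, it means among the compounds named here.

Measured so far in an ADME assay on cells (Fibroblast, Homo sapiens) for cytotoxicity, with a stated time of 48 h; a lower number here means a stronger inhibitor, a higher number a weaker inhibitor:

Compound 1 `O=[N+]([O-])c1ccc(CN2CCC(n3cc(CC(OCc4cc(-c5ccccc5)no4)c4ccc(Br)cc4)nn3)CC2)cc1` — > 25000 nM; this is a limit of the assay, not a number.
Compound 2 `O=[N+]([O-])c1ccc(CN2CCC(n3cc(CC(OCc4cc(-c5ccc(F)cc5)no4)c4ccc(Br)cc4)nn3)CC2)cc1` — > 25000 nM; also a limit.
Compound 3 `O=[N+]([O-])c1ccc(CN2CCC(n3cc(CC(OCc4cc(-c5ccccc5Br)no4)c4ccc(Br)cc4)nn3)CC2)cc1` — > 25000 nM; also a limit.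

Compound 3 thus stands only at a limit in this assay, and the same holds for the other two values shown (the limit of > 25000 nM in this assay, at which 3 of the 3 values shown sit). Compound 4 `O=[N+]([O-])c1ccc(CN2CCC(n3cc(CC(OCc4cc(-c5ccccc5F)no4)c4ccc(Br)cc4)nn3)CC2)cc1` differs from compound 3 by fluoro in place of bromo on an aromatic carbon. Going by the values given here, the steps that bear on this change are a step that the two limits leave unreadable from compound 1 to compound 2, a step that the two limits leave unreadable from compound 1 to compound 3 and a step that the two limits leave unreadable from compound 2 to compound 3; none of them can be read in size, since every value sits at the limit. The step that the limit leaves unreadable from compound 3 to compound 4 is therefore expected to leave compound 4 at the limit as well. Compound 4 is estimated at 30000 nM, within 15000 nM to 100000 nM.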

Compound 4, half-maximal inhibitory concentration: > 25000 nM
Compound 4 was reported as a limit; the forecaster's own chance of this, stated with the estimate: 85%; the middle value is on the limit's open side.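

Compound 4 gives > 25000 nM in this assay, which is a limit of the assay, so its steps from compound 1, compound 2 and compound 3 cannot be read in size. Left open is whether any of these phenyl substitutions changes the value in this assay at all: the limit of > 25000 nM in this assay, at which 4 of the 4 values shown sit.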